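From compound 3 to compound 4, at the limit

The compounds below may be only part of what the source reports. "The series", "measured", "known", "first", "only" and "open" are said of these compounds alone.

In an ADME assay on HEp-2 cells (Homo sapiens) for cytotoxicity (a higher number here means that more compound is tolerated, a lower number that less compound is tolerated), compound 1 (`Cc1ccc(NC(=O)CNS(=O)(=O)c2cccc3cccnc23)c(C)c1`) gives > 50000 nM as a limit of the assay. Compound 2 (`CCc1ccccc1NC(=O)[C@@H]1CCCN1S(=O)(=O)c1cccc2cccnc12`) gives > 50000 nM as a limit too. Compound 3 (`Cc1ccnc(C)c1NC(=O)[C@@H]1CCCN1S(=O)(=O)c1cccc2cccnc12`) gives > 50000 nM as a limit as well. Compound 3 thus stands with both others (the limit of > 50000 nM in this assay, at which 3 of the 3 values shown sit).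

Compound 4 (`Cc1ccc(C)c(NC(=O)[C@@H]2CCCN2S(=O)(=O)c2cccc3cccnc23)c1`) carries 2,5-dimethylphenyl in place of 2,4-dimethylpyridin-3-yl on an amide-type nitrogen. Within the data shown here, the one measured change at this place (a step that the two limits leave unreadable from compound 2 to compound 3) offers neither a size nor a direction. No step beyond the scatter is therefore expected in this assay for this change. The expected step is modest (a number no higher from compound 3 to compound 4 (the limit leaves the size open)). Compound 4 is estimated at 50000 nM within a range from 25000 nM to 100000 nM and is expected to be reported as a limit again.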

Compound 4, half-maximal cytotoxic concentration: 30900 nM
Beside the measured number, compound 4's estimate is 1.6-fold (0.21 log units) above it; measured number inside the range.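

In this assay the position on the amide-type nitrogen now yields a number instead of a limit, and 2,5-dimethylphenyl in place of 2,4-dimethylpyridin-3-yl gives an at least 1.6-fold lower number from compound 3 to compound 4 (0.20 log units; that floor lies within the scatter). Set against 2-ethylphenyl, the same group gives an at least 1.6-fold lower number from compound 2 to compound 4 (0.20 log units; that floor lies within the scatter). Both steps remain floors, because their starting compounds sit at a limit: the limit of > 50000 nM in this assay, at which 3 of the 4 values shown sit.

On these data alone, the true size of either step therefore stays open, and so does whether it exceeds the scatter. Also open, as far as these compounds go, is how the number would respond to an amine or a carboxylic acid on the phenyl ring in place of a methyl.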